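Side-chain change on a purine glycinamide: valine-type side chain

The compounds below may be only part of what the source reports. "The series", "measured", "known", "first", "only" and "open" are said of these compounds alone.

Measured compounds:
compound 1, `NC(=O)C[C@H](NC(=O)CN(c1nc(Cl)nc2[nH]cnc12)C1CC1)C(=O)O`, 20.1%;
compound 2, `O=C(O)CC[C@H](NC(=O)CN(c1nc(Cl)nc2[nH]cnc12)C1CC1)C(=O)O`, 44.7%.

Among the measured compounds shown here, in a functional assay on the whole organism (Tail, strain ICR) with Mus musculus as the target, in the tail flick test, with a stated time of 90 min, at a dose of 25 umol/kg by the oral route (a lower number here means a weaker effect, a higher number a stronger effect of the compound at the dose given), compound 2 stands highest of the two numbers known, and its nearest neighbour, compound 1, is set apart from it by a number 24.6 percentage points higher from compound 1 to compound 2 (beyond the scatter). Compound 3, `CC(C)[C@H](NC(=O)CN(c1nc(Cl)nc2[nH]cnc12)C1CC1)C(=O)O`, has not yet been measured. It differs from compound 2 by isopropyl in place of 2-carboxyethyl on a saturated chain carbon bound to an amide-type nitrogen and a carbonyl carbon. For the measured compounds named here, the one measured step concerns the end of this chain, not its removal, so it gives only indirect guidance: there the carbamoyl-to-carboxymethyl swap raised the read-out modestly. Going by the values given here, nothing among the measured compounds shows what happens when the chain carries no carboxyl at all. A step is therefore expected in this assay that is more likely downward than upward, of modest size at most, though a result within the scatter cannot be ruled out. Compound 3 is estimated to give 30%, between 10% and 55%, which is expected to mean a number 14.7 percentage points lower from compound 2 to compound 3 (beyond the scatter).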

Compound 3, a percentage reported as activity, at one dose (the size of the read-out at that dose, not a potency): 30.3%
For compound 3 the middle estimate is 0.3 percentage points below the measured one, within the range that was stated.
By their numbers in this assay, from the lowest: compound 1; then compound 3; then compound 2.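

In this assay, among the compounds shown here, isopropyl in place of 2-carboxyethyl gives a number 14.4 percentage points lower from compound 2 to compound 3 (beyond the scatter) and so shows for the first time that the read-out at this place persists, though at a reduced level, when the side chain carries no carboxyl group. Isopropyl in place of carbamoylmethyl gives a number 10.2 percentage points higher from compound 1 to compound 3 (beyond the scatter) at the same place, so the simple branched hydrocarbon group sits clear of both earlier side chains, under 2-carboxyethyl and over carbamoylmethyl. Nothing at hand explains either step.

The three side chains differ in length, branching and end group all at once, so these steps do not separate the contribution of each. How a carboxymethyl chain, a longer unbranched hydrocarbon chain, a benzyl group or a terminal amine would fare at this place remains open, as does the behaviour of these compounds at other doses.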